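From 3-methoxyphenyl to 3-chlorophenyl: one untested step

The compounds below may be only part of what the source reports. "The series", "measured", "known", "first", "only" and "open" are said of these compounds alone.

- compound 1 `COc1ccccc1Oc1c(N)nc(-c2ccccc2)nc1OCCO`: 31100 nM
- compound 2 `COc1cccc(-c2nc(N)c(Oc3ccccc3OC)c(OCCO)n2)c1`: 30500 nM

In a functional assay on B16 cells (Mus musculus) for cytotoxicity, read by CCK-8 assay, with a stated time of 24 h (on this read-out lower numbers stand for stronger inhibition and higher numbers for weaker inhibition), compound 2 stands level with compound 1, their values lying within the scatter of each other. Compound 3 `COc1ccccc1Oc1c(N)nc(-c2cccc(Cl)c2)nc1OCCO` has chloro in place of methoxy on an aromatic carbon. Among the compounds with values here, the only measured step that bears on this is a 1.0-fold lower number from compound 1 to compound 2 (0.01 log units; within the scatter), where methoxy replaced hydrogen on an aromatic carbon, and it lies within the scatter. Within the data shown here, no measured compound carries chloro, so the direction stays open and no step beyond the scatter is expected. The expected step is a 1.1-fold lower number from compound 2 to compound 3 (0.05 log units; within the scatter). For compound 3 the estimate is 27000 nM, with an expected range of 12000 nM to 60000 nM.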

Compound 3, half-maximal inhibitory concentration: 5010 nM
Beside the measured number, compound 3's estimate is 5.4-fold (0.73 log units) above it; the measured number lies below the stated range.
By their numbers in this assay, from the lowest: compound 3; then compounds 2 and 1 (each within the scatter of the next).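

The position looked indifferent while only hydrogen and methoxy stood there, but in this assay it shows a 6.1-fold lower number from compound 2 to compound 3 (0.78 log units; beyond the scatter) and a 6.2-fold lower number from compound 1 to compound 3 (0.79 log units; beyond the scatter) once chloro takes that place. The level result of methoxy for hydrogen therefore did not hold for every group at this position. Nothing measured here explains the gain.

Going by these compounds, whether bromo or an amine at this place would give a step of similar size stays open. So does whether chloro on another carbon of that ring would do the same.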